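The source may report more compounds than this note shows. Statements on the series, on what has been measured and on what is new or still open speak of the compounds shown alone.

Three members of one family of large ring-shaped peptides have been tested in a functional assay on P388 cells (Mus musculus) for cytotoxicity; a lower number here means a stronger inhibitor, a higher number a weaker inhibitor. Compound 1, with the structure `COc1ccc(C[C@H]2C(=O)N[C@@H](C)C(=O)N(C)[C@H]3Cc4ccc(cc4)Oc4cc(cc(N)c4OC)C[C@@H](C(=O)N[C@H](C)C(=O)N[C@@H](C)C(=O)N2C)N(C)C3=O)cc1`, gives 0.0071 ug/mL. Compound 2, with the structure `COc1ccc(C[C@H]2C(=O)N[C@@H](C)C(=O)N(C)[C@H]3Cc4ccc(cc4)Oc4cc(c(O)cc4OC)C[C@@H](C(=O)N[C@H](C)C(=O)N[C@@H](C)C(=O)N2C)N(C)C3=O)cc1`, gives 0.093 ug/mL. Compound 3, with the structure `COc1ccc(C[C@H]2C(=O)N[C@@H](C)C(=O)N(C)[C@H]3Cc4ccc(cc4)Oc4cc(c([N+](=O)[O-])cc4OC)C[C@@H](C(=O)N[C@H](C)C(=O)N[C@@H](C)C(=O)N2C)N(C)C3=O)cc1`, gives 0.056 ug/mL. On these numbers compound 3 stands second highest of the three: its nearest neighbour is compound 2, whose number is higher by an amount within the scatter, and its furthest is compound 1, whose number is lower by an amount beyond the scatter.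

The next compound to consider is compound 4, with the structure `COc1ccc(C[C@H]2C(=O)N[C@@H](C)C(=O)N(C)[C@H]3Cc4ccc(cc4)Oc4cc(c(N)cc4OC)C[C@@H](C(=O)N[C@H](C)C(=O)N[C@@H](C)C(=O)N2C)N(C)C3=O)cc1`. It differs from compound 3 in one place: amino in place of nitro on an aromatic carbon

Among the compounds with values here, only one measured step touches this part of the molecule, a 1.7-fold lower number from compound 2 to compound 3 (0.22 log units; within the scatter), and it stayed within the scatter. Within the data shown here, no measured step exchanges nitro for amino, so there is no direct guide. Compound 1 carries an amino group at a different position and shows the lowest number of the three, which hints that an amino group can sit well here, but it is not the same position. The expected step of a 1.9-fold lower number from compound 3 to compound 4 (0.27 log units; within the scatter) is therefore a modest move toward a lower number, with wide uncertainty. Compound 4 is estimated at 0.03 ug/mL, within a range from 0.008 ug/mL to 0.12 ug/mL.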

Compound 4, half-maximal inhibitory concentration: 0.7 ug/mL
Compound 4: the middle estimate sits 23-fold (1.37 log units) below what was measured, outside the stated range (above it).
By their numbers in this assay, from the lowest: compound 1; then compounds 3 and 2 (each within the scatter of the next); then compound 4.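

In this assay this aromatic carbon proves sensitive to the choice of group: amino in place of nitro brings a 13-fold higher number from compound 3 to compound 4 (1.10 log units; beyond the scatter) and amino in place of hydroxy brings a 7.5-fold higher number from compound 2 to compound 4 (0.88 log units; beyond the scatter) here. Both steps lie beyond the scatter, while hydroxy and nitro stayed within the scatter of each other, so among these three groups at this carbon, para to a fused ring, amino alone stands apart, with the highest number. Compound 1 also carries an amino group, on a different carbon of the ring, and compound 1 gives 0.0071 ug/mL against compound 4 at 0.7 ug/mL on the printed values, which suggests that the presence of amino does not settle the number on its own and that its place on the ring counts as well.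

Nothing shown here explains why amino behaves this way at this carbon. Going by these compounds, an acetamide, a dimethylamino group or a plain hydrogen on this carbon would show whether the higher number belongs to the free amino group itself, and that question stays open.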